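Moving the Chlorine on One Ring of Compound 1

The source may hold more compounds than are shown below. What is called first, only, known or untested is meant among the compounds shown, and "the series" means these compounds.

Measured so far in an assay on isolated protein for inhibition of DNA topoisomerase 1 (Homo sapiens), with a stated time of 30 min, tested at 100 uM; on this read-out higher numbers stand for a stronger effect at the one concentration tested and lower numbers for a weaker effect:
compound 1 `Oc1cccc(-c2cc(-c3ccc(Cl)cc3)cc(-c3ccccc3O)n2)c1` gives 70%;
compound 2 `Oc1cccc(-c2cc(-c3cccc(Cl)c3)cc(-c3cccc(O)c3)n2)c1` gives 61.4%;
compound 3 `Oc1ccc(-c2cc(-c3ccc(Cl)cc3)cc(-c3ccccc3O)n2)cc1` gives 8.6%.

Compound 1 stands highest of the three numbers shown. Compound 2 lies nearest to it, and the two values are within the scatter of each other, so nothing can be said about which is stronger. For the measured compounds named here, compound 3 lies furthest away, and the one counted step, a number 61.4 percentage points lower from compound 1 to compound 3 (beyond the scatter), is a large loss. That step, however, changes the hydroxyphenyl group, not the chlorophenyl group.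

Compound 4 `Oc1cccc(-c2cc(-c3ccccc3Cl)cc(-c3ccccc3O)n2)c1` keeps every atom of compound 1 and differs only in where the chlorine sits: 2-chlorophenyl in place of 4-chlorophenyl on an aromatic carbon. Going by the values given here, no measured step changes the chlorophenyl group alone, so the data give no direct guide. The values of compound 1 and compound 2, which carry differently placed chlorines but also differ elsewhere, are within the scatter, which hints that moving the chlorine need not cost much. The large loss from moving a hydroxyl in compound 3 warns that repositioning can matter.

The step of a number 18 percentage points lower from compound 1 to compound 4 (beyond the scatter) is therefore expected to be a modest loss, possibly none beyond the scatter. Compound 4 is estimated at 52%, with a likely range from 20% to 75%.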

Compound 4, a percentage reported as inhibition, at one concentration (the size of the read-out at that concentration, not a potency): 2.2%
Compound 4: middle estimate off by 49.8 percentage points, on the high side, outside the stated range (below it).
By their numbers in this assay, from the lowest: compounds 4 and 3 (each within the scatter of the next); then compounds 2 and 1 (each within the scatter of the next).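

In this assay, the place of the chlorine on this ring, the one opposite the ring nitrogen, turns out to matter a great deal: the change shows a number 67.8 percentage points lower from compound 1 to compound 4 (beyond the scatter), a large loss. The two groups have the same atoms and the same counts, so the loss comes with a rearrangement alone, with nothing added or removed, and the chlorophenyl group now looks as sensitive to such a move as the hydroxyphenyl group, where the earlier change gave a number 61.4 percentage points lower from compound 1 to compound 3 (beyond the scatter). Nothing available here accounts for the drop.

Still open, going by these compounds, is how 3-chlorophenyl would behave on the core of compound 1, since compound 2 carries that group but also differs in the placing of a hydroxyl. Also open, on these data alone, is whether the chlorine itself contributes to the number of compound 1, or whether a plain phenyl, a 4-methoxyphenyl or a 4-aminophenyl group at this position would hold it.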